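Propoxy in place of bromo, judged from two neighbours

The compounds below may be only part of what the source reports. "The series", "measured", "known", "first", "only" and "open" are said of these compounds alone.

Of the compounds shown here, three share one core and have been measured in a functional assay on MCF7 cells (Homo sapiens) for cytotoxicity; on this read-out lower numbers stand for stronger inhibition and higher numbers for weaker inhibition. Compound 1 `CCC(CO)Nc1nc(NCc2ccccc2)c2nc(Br)n(C(C)C)c2n1` gives 53000 nM. Compound 2 `CCC(CO)Nc1nc(NCc2ccccc2)c2nc(O)n(C(C)C)c2n1` gives 65000 nM. Compound 3 `CCC(CO)Nc1nc(NCc2ccccc2)c2nc(S)n(C(C)C)c2n1` gives 55000 nM. Compound 1 stands at the lowest of the three numbers, but its separation from the others is within the scatter: a 1.2-fold higher number from compound 1 to compound 2 (0.09 log units; within the scatter), and a 1.0-fold higher number from compound 1 to compound 3 (0.02 log units; within the scatter). The remaining pair is likewise close, a 1.2-fold lower number from compound 2 to compound 3 (0.07 log units; within the scatter).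

Compound 4 `CCCOc1nc2c(NCc3ccccc3)nc(NC(CC)CO)nc2n1C(C)C` has not yet been measured. It differs from compound 1 in one place: propoxy in place of bromo on an aromatic carbon. The two measured steps at this same aromatic carbon, hydroxy in place of bromo and sulfanyl in place of bromo, both stayed within the scatter, so the position has so far tolerated replacement of bromo without a change worth noting. Among the measured compounds shown here, no measured compound carries propoxy here, so the expectation rests on those two steps alone. Compound 4 is therefore expected to give a number close to that of compound 1, with a 1.1-fold lower number from compound 1 to compound 4 (0.03 log units; within the scatter) as the expected step. Compound 4 is estimated at 50000 nM, within a range from 20000 nM to 125000 nM.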

Compound 4, half-maximal inhibitory concentration: 50000 nM
The estimate for compound 4 equals the measured number at the digits printed, and the stated range covers the measured number.
By their numbers in this assay, from the lowest: compounds 4, 1, 3 and 2 (each within the scatter of the next).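

Compound 4 shows that the tolerance at this aromatic carbon, between two ring nitrogen atoms and next to the ring atom that bears an isopropyl group, extends beyond single-atom and small replacements of bromo to a propoxy chain: in this assay there is a 1.1-fold lower number from compound 1 to compound 4 (0.03 log units; within the scatter). The comparisons with the other two neighbours read the same way, with a 1.1-fold lower number from compound 3 to compound 4 (0.04 log units; within the scatter) and a 1.3-fold lower number from compound 2 to compound 4 (0.11 log units; within the scatter), the last of these being the addition of propyl to the oxygen on the aromatic ring. No independent data are available to explain why the number stays flat across these groups.

The compounds shown leave open whether an amine, a carboxylic acid or a longer chain at this carbon would shift the number beyond the scatter. They also leave open whether a replacement of the isopropyl group would do so.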